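Dropping the Carboxymethyl Group: Plasma Stability Outlook

The compounds below may be only part of what the source reports. "The series", "measured", "known", "first", "only" and "open" are said of these compounds alone.

Compound 1 `NCc1ccc(C(=O)Nc2ccncc2F)cc1-c1cccc(C(=O)Nc2ccc(CC(=O)O)cc2)c1`: in an ADME assay on a cell-free system (plasma, Homo sapiens) for metabolic stability, read by LC-MS (on this read-out higher numbers stand for a longer-lived compound and lower numbers for a shorter-lived compound), compound 1 gives > 2 h, which is a limit of the assay and not a number.
Compound 2 `NCc1ccc(C(=O)Nc2ccncc2F)cc1-c1cccc(C(=O)Nc2cccc(CC(=O)O)c2)c1`: in this assay compound 2 gives > 2 h, again a limit of the assay.
Compound 3 `NCc1ccc(C(=O)Nc2ccncc2F)cc1-c1cccc(NC(=O)c2cc(C(=O)O)ccc2F)c1`: in this assay compound 3 gives > 2 h, also a limit of the assay.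

Compound 2 therefore stands at the edge of what this assay reports; all three values sit together at the limit of > 2 h in this assay, at which 3 of the 3 values shown sit, so none of them can be placed in order. The step that the two limits leave unreadable from compound 1 to compound 2 is likewise unreadable. Compound 4 `NCc1ccc(C(=O)Nc2ccncc2F)cc1-c1cccc(C(=O)Nc2ccccc2)c1` differs from compound 2 by hydrogen in place of carboxymethyl on an aromatic carbon. Going by the values given here, no measured step shows what removing a carboxymethyl group does here, so the only guide is that every compound so far reached the limit. On that basis compound 4 is expected to remain long-lived, with an estimated 4 h, between 1.5 h and 12 h. The expected step that the limit leaves unreadable from compound 2 to compound 4 is therefore not beyond the scatter, pending the actual measurement of compound 4.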

Compound 4, half-life: > 2 h
Compound 4 was reported as a limit; the forecaster's own chance of this, stated with the estimate: 70%; the middle value is on the limit's open side.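

In this assay compound 4 gives > 2 h, which is a limit and not a number. No step linking compound 4 to compound 1 or compound 2 can be read: the limit of > 2 h in this assay, at which 4 of the 4 values shown sit.

The compounds shown leave open how long each one actually lasts, and whether removing the carboxymethyl group changes that at all.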